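This account rests on a few compounds, and the source may have more. Where it says the series, first, only, none or still open, it means among the compounds named here.

Among the compounds with values here, in a functional assay on the whole organism (artery, strain albino) with Rattus norvegicus as the target, with a stated time of 720 min, at a dose of 10 mg/kg by the oral route (a lower number here means less inhibition, a higher number more inhibition at the dose given (going by the name of the read-out)), compound 1 `COc1ccc(C2N=C(SCc3ccccc3)NC(C)=C2C(=O)Nc2ccc(F)cc2)cc1OC` gives 1.5%, the lowest of the two numbers known. Within the data shown here, compound 2 `COc1ccc(C2N=C(SCc3ccccc3Cl)NC(C)=C2C(=O)Nc2ccc(F)cc2)cc1OC` gives 23.2%; the one measured step is a number 21.7 percentage points higher from compound 1 to compound 2 (beyond the scatter) and arises from a chloro in place of hydrogen on an aromatic carbon. Compound 3 `CC1=C(C(=O)Nc2ccc(F)cc2)C(c2ccc([N+](=O)[O-])cc2)N=C(SCc2ccccc2)N1` differs from compound 1 in a different place: 4-nitrophenyl in place of 3,4-dimethoxyphenyl on a saturated ring carbon. Among the measured compounds shown here, no measured step touches this place, so the only step known gives no direct guide. With the low value of compound 1 as the sole anchor, compound 3 is expected to show a number 8.5 percentage points higher from compound 1 to compound 3 (within the scatter) and an estimated 10%, ranging from 0% to 35%.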

Compound 3, a percentage reported as inhibition, in the whole organism at one dose (the size of the read-out at that dose, not a potency): 27.3%
For compound 3 the middle estimate is 17.3 percentage points below the measured one, and the stated range covers the measured number.
By their numbers in this assay, from the lowest: compound 1; then compounds 2 and 3 (each within the scatter of the next).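

On the saturated ring carbon next to the ring nitrogen, the aryl group proves to matter in this assay, where 4-nitrophenyl in place of 3,4-dimethoxyphenyl gives a number 25.8 percentage points higher from compound 1 to compound 3 (beyond the scatter) and so lifts the low number of compound 1 by a change away from the benzylsulfanyl group. No measurement shown explains this rise. The compounds shown leave open whether the nitro group or the loss of the two methoxy groups accounts for it. They also leave open what a plain phenyl, a 4-aminophenyl or a 4-carboxyphenyl would give on this carbon.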